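Fluorines in place of bromines on the sulfonamide aryl group

The source may report more compounds than this note shows. Statements on the series, on what has been measured and on what is new or still open speak of the compounds shown alone.

Measured compounds:
compound 1, `COc1ccc(S(=O)(=O)Nc2cc(Cl)c(Cl)cc2Cl)cc1N1CCNCC1`, 5.01 nM
compound 2, `COc1ccc(S(=O)(=O)Nc2cc(Cl)cc(Cl)c2Br)cc1N1CCNCC1`, 3.16 nM
compound 3, `COc1ccc(S(=O)(=O)Nc2cc(Br)cc(Cl)c2Br)cc1N1CCNCC1`, 3.98 nM

In an assay on isolated protein for binding affinity to 5-hydroxytryptamine receptor 6 (Homo sapiens) (a higher number here means a weaker inhibitor, a lower number a stronger inhibitor), compound 3 sits among its two neighbours: a 1.3-fold lower number from compound 1 to compound 3 (0.10 log units; within the scatter) and a 1.3-fold higher number from compound 2 to compound 3 (0.10 log units; within the scatter), so all three numbers lie within the usual scatter of one another. Compound 4, `COc1ccc(S(=O)(=O)Nc2cc(F)cc(F)c2Cl)cc1N1CCNCC1`, differs from compound 3 by 2-chloro-3,5-difluorophenyl in place of 2,5-dibromo-3-chlorophenyl on a sulfonamide nitrogen. The measured steps that bear on this are a 1.6-fold lower number from compound 1 to compound 2 (0.20 log units; within the scatter) and a 1.3-fold higher number from compound 2 to compound 3 (0.10 log units; within the scatter), each a swap of chloro and bromo that changed nothing beyond the scatter. Among the measured compounds shown here, no measured compound carries fluorine on this ring, so the shift to two fluorines is untested. Compound 4 is therefore expected to give a number near that of compound 3, with a modest move upward allowed, a 2.0-fold higher number from compound 3 to compound 4 (0.30 log units; within the scatter); the estimate for compound 4 is 8 nM, ranging from 3 nM to 25 nM.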

Compound 4, inhibition constant: 31.6 nM
Compound 4: the middle estimate sits 4.0-fold (0.60 log units) below what was measured, and the stated range ends below it.
By their numbers in this assay, from the lowest: compounds 2, 3 and 1 (each within the scatter of the next); then compound 4.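

In this assay the swaps of chloro and bromo stayed within the scatter, but 2-chloro-3,5-difluorophenyl on the sulfonamide nitrogen does not: there is a 7.9-fold higher number from compound 3 to compound 4 (0.90 log units; beyond the scatter) and a 10-fold higher number from compound 2 to compound 4 (1.00 log units; beyond the scatter) as well as a 6.3-fold higher number from compound 1 to compound 4 (0.80 log units; beyond the scatter) here. Compound 1 also carries no bromine, so losing bromine alone does not account for the rise, and this aryl group is shown to be sensitive to its halogens. Nothing available explains the rise. As far as these compounds go, whether a single fluorine is enough remains open, as does how a methyl or methoxy group would behave on this aryl group.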